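Swapping Cyclopentyl for Isobutyl in a Glucagon Receptor Antagonist

This account rests on a few compounds, and the source may have more. Where it says the series, first, only, none or still open, it means among the compounds named here.

Measured so far:
compound 1 `O=C(O)CCNC(=O)c1ccc(C(Oc2ccc(-n3cc(C(F)(F)F)cn3)cc2)C2CCCC2)cc1`: 4000 nM
compound 2 `CCCC(Oc1ccc(-n2cccn2)cc1)c1ccc(C(=O)NCCC(=O)O)cc1`: > 55000 nM

The measure throughout is a functional assay on cells for antagonist activity at Glucagon receptor (Homo sapiens), read by cAMP accumulation, in the presence of a further agent that is not named here; a lower number here means a stronger inhibitor, a higher number a weaker inhibitor. In this assay, going by the values given here, compound 1 gives 4000 nM, the only plain number among the values shown. Compound 2 reaches only (the limit of > 55000 nM in this assay, at which 1 of the 2 values shown sits), which is a limit of the assay and not a number. Compound 2 differs from compound 1 in more than one place, so the two values show no more than that one yields a number and the other a limit.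

Compound 3 `CC(C)CC(Oc1ccc(-n2cc(C(F)(F)F)cn2)cc1)c1ccc(C(=O)NCCC(=O)O)cc1` has not yet been measured. It differs from compound 1 by isobutyl in place of cyclopentyl on a saturated chain carbon bound to an aromatic carbon and an oxygen on an aromatic ring. Among the compounds with values here, no step between measured compounds tells how such a change acts in this assay. The step from compound 1 to compound 3 is expected to be a 1.5-fold higher number from compound 1 to compound 3 (0.18 log units; within the scatter), modest and possibly within the scatter, leaning toward weaker inhibition. For compound 3 the estimate is 6000 nM, between 2000 nM and 20000 nM.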

Compound 3, antagonist equilibrium constant: 3400 nM
Beside the measured number, compound 3's estimate is 1.8-fold (0.25 log units) above it; the measured number falls inside the stated range.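

At the saturated chain carbon bound to an aromatic carbon and an oxygen on an aromatic ring, isobutyl in place of cyclopentyl gives a 1.2-fold lower number from compound 1 to compound 3 (0.07 log units; within the scatter) in this assay, so this pair cannot be told apart. In this one pair, then, the closed ring of cyclopentyl is not required for a plain number, since the open chain of isobutyl in compound 3 also gives one. Nothing measured here says why the two groups read alike.

Compound 2 stays at > 55000 nM, a limit of the assay and not a number, and it differs from the other compounds in more than one place, so it cannot be read as a step. On these data alone, how an amine or a phenyl ring on this same carbon would read remains open.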